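Ether series notes: from compound 3 to compound 4

This account rests on a few compounds, and the source may have more. Where it says the series, first, only, none or still open, it means among the compounds named here.

Three compounds of the series are measured in a functional assay on cells (T-cell line, Homo sapiens) for inhibition; a lower number here means a stronger inhibitor, a higher number a weaker inhibitor. Compound 1 `COc1ccc(CCCN2CCC(CO)CC2)cc1` gives a limit in this assay, > 20000 nM, and that limit is the limit of > 20000 nM in this assay, at which 1 of the 3 values shown sits. Compound 2 `COc1ccc(CCCN2CCC(COCc3ccccc3)CC2)cc1` gives 2100 nM in this assay, while compound 3 `CCCCN1CCC(COC(c2ccccc2)c2ccccc2)CC1` gives 14000 nM, the highest of the two numbers; compound 2 and compound 3 differ in two places, so their values stand side by side without a step between them. Within the data shown here, the single measured one-place step, an at least 9.5-fold lower number from compound 1 to compound 2 (0.97 log units; beyond the scatter), is the only guide: benzyl in place of hydrogen on the oxygen lowered the number. Compound 4 `c1ccc(C(OCC2CCN(CC3CCc4ccccc4C3)CC2)c2ccccc2)cc1` carries 1,2,3,4-tetrahydronaphthalen-2-yl in place of propyl on a saturated chain carbon bound to an amine nitrogen in a ring. Among the measured compounds shown here, this change also brings one six-membered aromatic ring of carbon only and one six-membered non-aromatic ring, now on the amine side, where no measured step exists. A modest lowering of the number is expected, with less confidence than for the ether step, giving a 5.6-fold lower number from compound 3 to compound 4 (0.75 log units; beyond the scatter). Compound 4 is expected near 2500 nM in this assay, between 500 nM and 12000 nM.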

Compound 4, half-maximal inhibitory concentration: 5600 nM
Estimate against measurement, compound 4: 2.2-fold (0.35 log units) below, within the range that was stated.
By their numbers in this assay, from the lowest: compound 2; then compound 4; then compound 3. At a limit, above all of these: compound 1.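

In this assay the amine side of the series now has a measured one-place step, a 2.5-fold lower number from compound 3 to compound 4 (0.40 log units; beyond the scatter), with 1,2,3,4-tetrahydronaphthalen-2-yl in place of propyl on a saturated chain carbon bound to an amine nitrogen in a ring. This place therefore takes a group with one aromatic and one non-aromatic ring instead of an open chain without a rise in the number, and the earlier ether step could not show this. Nothing measured here gives a cause for this step.

On these data alone, whether the lowering follows the aromatic ring, the non-aromatic ring or simply the added carbons stays open, and a cyclohexyl group or a longer chain at this place would separate these. As far as these compounds go, how a carboxylic acid or an amine on the entering group would read in this assay is also open.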